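Iodo for tert-butyl on two different cores

A few compounds are considered here, and "the series" means these few. Any claim that something is new, unique, unknown or untested is made for them only; others in the source may bear on it.

Compound 1 `CC(C)(C)c1ccc(NC2=NCCO2)cc1` and compound 2 `Ic1ccc(NC2=NCCO2)cc1` share one core and differ by iodo in place of tert-butyl on an aromatic carbon. In a functional assay on HT-29 cells (Homo sapiens) for inhibition, read by sulforhodamine B assay, with a stated time of 48 h (a lower number here means a stronger inhibitor of growth, a higher number a weaker inhibitor of growth), compound 1 gives 1500 nM, and compound 2 gives 1300 nM; the step is a 1.2-fold lower number from compound 1 to compound 2 (0.06 log units; within the scatter). Compound 3 `CC(C)(C)c1ccc(NC(=O)NC(=O)CCl)cc1` is built on another core; the difference between the two cores is not broken down here. In this assay compound 3 gives 3300 nM, the highest of the three numbers, beyond the scatter from both compound 1 and compound 2. Compound 4 `O=C(CCl)NC(=O)Nc1ccc(I)cc1` is not yet measured. It differs from compound 3 by iodo in place of tert-butyl on an aromatic carbon. This is the same kind of change as that from compound 1 to compound 2, not the same: on the first core the site is para to a group of 6 heavy atoms, on the second core it is para to a group of 8 heavy atoms. In this assay the expected step is a 1.2-fold lower number from compound 3 to compound 4 (0.07 log units; within the scatter), small like the earlier one. Going by the values given here, this expectation rests on the single precedent a 1.2-fold lower number from compound 1 to compound 2 (0.06 log units; within the scatter), and the different core offers no further check. Compound 4 is therefore estimated at 2800 nM, with a range from 1300 nM to 6000 nM.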

Compound 4, concentration for 50% growth inhibition: 6900 nM
Estimate against measurement, compound 4: 2.5-fold (0.39 log units) below; the whole stated range lies below it.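

In this assay, iodo in place of tert-butyl on the core of compound 3 gives a 2.1-fold higher number from compound 3 to compound 4 (0.32 log units; beyond the scatter), a modest step. Set beside the same change on the core of compound 1, this step cannot be separated from the earlier one: the same change on two cores in this assay, a 1.2-fold lower number (0.06 log units; within the scatter) from compound 1 to compound 2 and a 2.1-fold higher number (0.32 log units; beyond the scatter) from compound 3 to compound 4, 2.4-fold (0.38 log units) apart, within the scatter of two such steps With a single pair on each core, a step beyond the scatter on one and a step within it on the other do not show that the core alters the effect of this change, nor do they prove that the effect carries over unchanged, and they give no reason for the size of either step.

Still open, going by these compounds, is whether other groups at this aromatic carbon, such as an amine, a carboxylic acid or a longer chain, would give matching steps on both cores. Also open, on these data alone, is whether further pairs on each core would bring the steps for this change closer together or set them apart.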